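This account rests on a few compounds, and the source may have more. Where it says the series, first, only, none or still open, it means among the compounds named here.

Compound 1 `CCCn1cnc2c(N)nc(NCc3ccccc3)nc21` and compound 2 `CCCn1c(Br)nc2c(N)nc(NCc3ccccc3)nc21` share one core and differ in a single place. In an assay on CHO cells for displacement of a labelled ligand from adenosine receptor A1 (Homo sapiens) (on this read-out lower numbers stand for stronger inhibition and higher numbers for weaker inhibition), compound 1 gives 7600 nM, while compound 2 gives 358 nM. The change between them is bromo in place of hydrogen on an aromatic carbon and it produced a step of a 21-fold lower number from compound 1 to compound 2 (1.33 log units; beyond the scatter).

Compound 3 `CCCn1cnc2c(NCCCc3ccccc3)ncnc21` is built on a different core, and the difference between the two cores is not broken down here. In this assay, going by the values given here, compound 3 gives 18600 nM, the highest of the three numbers measured so far. Compound 4 `CCCn1c(Br)nc2c(NCCCc3ccccc3)ncnc21` has not yet been measured; relative to compound 3 it carries bromo in place of hydrogen on an aromatic carbon. The place of the change is described in the same words for both pairs, so the same change is being made on two different cores, the two occurrences being the only ones among these compounds.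

Among the compounds with values here, the expectation for compound 4 rests on the step of a 21-fold lower number from compound 1 to compound 2 (1.33 log units; beyond the scatter), which is the single measured example of this change. The core of compound 3 is not the core of compound 1, and nothing measured here shows how the change behaves on that core, so a smaller gain is taken as the more cautious expectation. Compound 4 is accordingly expected to give about 2300 nM in this assay. For compound 4 this means an expected step of an 8.1-fold lower number from compound 3 to compound 4 (0.91 log units; beyond the scatter). For compound 4 the expected range runs from 700 nM to 7000 nM.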

Compound 4, inhibition constant: 2670 nM
The estimate for compound 4 lay 1.2-fold (0.06 log units) below the measured number; the range from low to high includes it.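

Carried to the core of compound 3, bromo in place of hydrogen on an aromatic carbon again lowers the number in this assay, with a 7.0-fold lower number from compound 3 to compound 4 (0.84 log units; beyond the scatter), so the direction of the step is the same on both cores. Going by these compounds alone, the size of the step does not carry over unchanged, however, and the gain on the core of compound 3 is the smaller of the two: the same change on two cores in this assay, a 21-fold lower number (1.33 log units; beyond the scatter) from compound 1 to compound 2 and a 7.0-fold lower number (0.84 log units; beyond the scatter) from compound 3 to compound 4, 3.0-fold (0.48 log units) apart, beyond the scatter of two such steps With only two cores, this shows that the change can be moved from one core to the other with its direction kept, but it does not show that the direction would hold on a third core, nor which difference between the two cores goes with the gap in size.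

The compounds shown leave open whether another group on the aromatic carbon between two ring nitrogen atoms, such as chloro, methyl or an amine, would lower the number in this assay as bromo does. They also leave open whether a longer chain in place of the propyl group would alter the size of the step on either core.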